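A few compounds are considered here, and "the series" means these few. Any claim that something is new, unique, unknown or untested is made for them only; others in the source may bear on it.

Measured so far in a physicochemical assay for solubility, using the shake flask method, in simulated intestinal fluid, measured as kinetic solubility, with a stated time of 2 h, at 25 degrees C, at pH 6.5 (on this read-out higher numbers stand for higher solubility and lower numbers for lower solubility), are two values, both of them limits:
- compound 1 (`Cc1noc(-c2nc(C)c3c(c2N)C(=O)N(Cc2ccc(Br)cc2)C3=O)n1`) gives < 5000 nM as a limit
- compound 2 (`Cc1noc(-c2nc(C)c3c(c2N)C(=O)N(Cc2ccccc2C(F)(F)F)C3=O)n1`) gives < 5000 nM as a limit

Compound 2 stands only at a limit (< 5000 nM) and has no readable number. Compound 3 (`Cc1noc(-c2nc(C)c3c(c2N)C(=O)N(Cc2ccc(OC(F)F)cc2)C3=O)n1`) differs from it as follows (4-(difluoromethoxy)phenyl in place of 2-(trifluoromethyl)phenyl on a saturated chain carbon bound to an amide-type nitrogen in a ring) at the same place on the shared core. Within the data shown here, the only measured step (a step that the two limits leave unreadable from compound 1 to compound 2) bears on this change, but gives no size to carry over. The evidence so far is the limit of < 5000 nM in this assay, at which 2 of the 2 values shown sit, and nothing more. No step beyond the scatter is expected in this assay, and no direction is expected. The expected step is a step that the limit leaves unreadable from compound 2 to compound 3 by estimate. For compound 3 the estimated value is 3000 nM with an expected range from 1000 nM to 9000 nM in this estimate.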

Compound 3, solubility: < 5000 nM
Compound 3: a limit, no number; the forecaster's own chance of this, stated with the estimate: 85%; the middle value lies beyond the limit too.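

No step can be read among compound 1, compound 2 and compound 3 in this assay, as all three give only a limit: the limit of < 5000 nM in this assay, at which 3 of the 3 values shown sit.

The compounds shown leave open how far the three lie under that limit and whether their groups on the saturated chain carbon differ at all.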